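Pentyl for isopropyl on the urea aryl ring

The compounds below may be only part of what the source reports. "The series", "measured", "known", "first", "only" and "open" are said of these compounds alone.

In an ADME assay on the whole organism with Oryza sativa as the target, tested at 0.1 uM (on this read-out lower numbers stand for a stronger effect and higher numbers for a weaker effect at the one concentration tested), three close relatives of one urea have been measured. Compound 1 `Cc1ccccc1NC(=O)N[C@H](C)c1ccccc1` gives 100%, compound 2 `CC(C)c1ccc(NC(=O)N[C@H](C)c2ccccc2)cc1` gives 99%, and compound 3 `CC(C)c1ccc(NC(=O)N[C@@H](C)c2ccccc2)cc1` gives 98%. Compound 2 stands second highest of these three numbers, within the scatter of both its neighbours. Going by the values given here, the only step measured between two compounds differing in one place is the change in configuration at the stereocentre, a number 1 percentage points lower from compound 2 to compound 3 (within the scatter), a step that lies within the scatter and is tied to the fact that compounds 2 and 3 differ only in the configuration as drawn.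

Compound 4 `CCCCCc1ccc(NC(=O)N[C@H](C)c2ccccc2)cc1` is the next compound to be measured. It differs from compound 2 by pentyl in place of isopropyl on an aromatic carbon. Among the compounds with values here, none of the measured steps touches the group on the aromatic ring, so the stereo step gives no guidance on this change, and the three values themselves sit close together. A step of no size beyond the scatter is therefore expected in this assay, so that the step from compound 2 to compound 4 is estimated as a number 2 percentage points lower from compound 2 to compound 4 (within the scatter). Compound 4 is expected to give 97%, within a range from 85% to 100%.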

Compound 4, a percentage reported as activity, at one concentration (the size of the read-out at that concentration, not a potency): 100%
Compound 4: the middle estimate sits 3 percentage points below what was measured; the range from low to high includes it.
By their numbers in this assay, from the lowest: compounds 3, 2, 1 and 4 (each within the scatter of the next).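

In this assay, going by these compounds alone, pentyl in place of isopropyl on the aromatic carbon para to a large group gives a number 1 percentage points higher from compound 2 to compound 4 (within the scatter), the first measured step at this position. Together with the stereo step, this gives a second kind of one-place step that lies within the scatter, so neither the configuration at the chain carbon nor this exchange of groups separates the compounds at the one concentration tested. Nothing available here bears on why pentyl and isopropyl read alike at this position.

The compounds shown leave open whether any group at this position can produce a step beyond the scatter. An amine or a carboxylic acid in place of pentyl would test this with a group of a different kind from the two chains compared here.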